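Changing one phenyl group on a shared core

The source may report more compounds than this note shows. Statements on the series, on what has been measured and on what is new or still open speak of the compounds shown alone.

In a functional assay on K562 cells (Homo sapiens) for antiproliferative activity, read by MTT assay, with a stated time of 48 h (a lower number here means a stronger inhibitor, a higher number a weaker inhibitor), compound 1 (`COc1ccc(CN2C(=O)C(=O)c3cc(-c4cc(OC)cc(OC)c4)ccc32)cc1`) gives 510 nM and compound 2 (`COc1ccc(CN2C(=O)C(=O)c3cc(-c4ccc(F)c(Cl)c4)ccc32)cc1`) gives 380 nM so these two readings sit level. Compound 2 therefore stands alongside compound 1 and not clearly apart from it.

Compound 3 (`COc1ccc(CN2C(=O)C(=O)c3cc(-c4ccc(C(F)(F)F)cc4)ccc32)cc1`) has not yet been measured. It differs from compound 2 in one place (4-(trifluoromethyl)phenyl in place of 3-chloro-4-fluorophenyl on an aromatic carbon): 4-(trifluoromethyl)phenyl in place of 3-chloro-4-fluorophenyl on an aromatic carbon of the shared core.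

For the measured compounds named here, only one measured step bears on this change. It is a 1.3-fold lower number from compound 1 to compound 2 (0.13 log units; within the scatter) and it also swaps one substituted phenyl group for another on that same aromatic carbon. Going by the values given here, that single step is thin evidence, and no measured compound carries a trifluoromethyl group, so the range must stay wide.

The estimated change is a 1.1-fold lower number from compound 2 to compound 3 (0.04 log units; within the scatter) and so no shift beyond the scatter is expected in this assay for now. For compound 3 the estimated value is 350 nM with an expected range from 100 nM to 1000 nM for this reading.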

Compound 3, half-maximal inhibitory concentration: 350 nM
For compound 3 middle estimate and measured number coincide at the digits printed; measured number inside the range.
By their numbers in this assay, from the lowest: compounds 3, 2 and 1 (each within the scatter of the next).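

In this assay, the new reading adds two steps at the same aromatic carbon: a 1.1-fold lower number from compound 2 to compound 3 (0.04 log units; within the scatter) and a 1.5-fold lower number from compound 1 to compound 3 (0.16 log units; within the scatter). For the compounds shown here, both lie within the scatter, so 4-(trifluoromethyl)phenyl, 3-chloro-4-fluorophenyl and 3,5-dimethoxyphenyl all give readings that sit level, and what had been a single comparison between two substituted phenyl groups now holds across three, with no compound among them going against it. No available evidence explains why these three groups read alike.

All three groups are substituted phenyl rings, so the compounds shown leave open whether this level reading would survive a real departure from that type, such as a phenyl ring carrying an amine or a carboxylic acid, or a longer alkyl chain in place of the ring. They also leave open whether the same flat picture holds when the 4-methoxyphenylmethyl group on the ring nitrogen of the shared core is changed, since that part stays the same in compound 1, compound 2 and compound 3.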